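A few compounds are considered here, and "the series" means these few. Any claim that something is new, unique, unknown or untested is made for them only; others in the source may bear on it.

Measured in a functional assay on A549 cells (Homo sapiens) for antiproliferative activity, read by MTT assay, with a stated time of 48 h; on this read-out lower numbers stand for stronger inhibition and higher numbers for weaker inhibition:
- compound 1 `COc1cccc(-c2nc3cccc(-c4cc(OC)c(OC)c(OC)c4)c3o2)c1`: 3500 nM
- compound 2 `COc1ccc(-c2nc3c(-c4cc(OC)c(OC)c(OC)c4)cccc3o2)cc1OC`: 20100 nM

Compound 2 holds the higher of the two numbers, and its gap to compound 1 lies beyond the scatter. Compound 3 `COc1ccc(-c2nc3c(-c4cc(OC)c(OC)c(OC)c4)cccc3o2)cc1F` has fluoro in place of methoxy on an aromatic carbon, ortho to a methoxy group and meta to a large group, so 3,4-dimethoxyphenyl becomes 3-fluoro-4-methoxyphenyl (fluoro in place of methoxy on an aromatic carbon). Within the data shown here, no measured pair differs in one place, so this change has no direct precedent. With so little to go on, a small move toward a lower number in this assay is expected, possibly none beyond the scatter. The estimated change is a 1.5-fold lower number from compound 2 to compound 3 (0.19 log units; within the scatter). For compound 3 the expected value is 13000 nM, with an estimated range of 4500 nM to 38000 nM.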

Compound 3, half-maximal inhibitory concentration: > 25000 nM
Compound 3 gave a limit, no number; the forecaster's own chance of this, stated with the estimate: 10%; middle value at least 1.9-fold (0.28 log units) away from the limit.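

Compound 3 gives a limit of the assay, not a number: the limit of > 25000 nM in this assay, at which 1 of the 3 values shown sits.

In this assay, among these compounds, this pair supplies the first one-place step, an at least 1.2-fold higher number from compound 2 to compound 3 (0.09 log units; that floor lies within the scatter), so fluoro in place of methoxy on this aromatic carbon, ortho to a methoxy group, brings no move toward a lower number. Going by these compounds, the floor of that step lies within the scatter, so the pair shows no gain for 3-fluoro-4-methoxyphenyl over 3,4-dimethoxyphenyl, while the true size of any loss stays unknown.

On these data alone, how far the true value of compound 3 lies past its limit remains open, as does whether the same change would read alike on the aryl group of compound 1. Also open, as far as these compounds go, is whether a hydroxy group or an amine on this carbon would give a lower number than compound 2.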